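This account rests on a few compounds, and the source may have more. Where it says the series, first, only, none or still open, it means among the compounds named here.

In a functional assay on MCF7 cells (Homo sapiens) for antiproliferative activity, read by MTT assay, with a stated time of 72 h (on this read-out lower numbers stand for stronger inhibition and higher numbers for weaker inhibition), compound 1 (`O=C(Nc1ccc(Nc2nccc(NC3CCCCC3)n2)cc1)Nc1ccc(Cl)c(C(F)(F)F)c1`) gives 10800 nM, compound 2 (`O=C(Nc1ccc(Nc2nccc(NC3CC3)n2)cc1)Nc1ccc(Cl)c(C(F)(F)F)c1`) gives 38300 nM and compound 3 (`O=C(Nc1ccc(Nc2nccc(NC3CCCC3)n2)cc1)NC1CCCCC1`) gives 19200 nM. Compound 3 thus stands within the scatter of each of the other two, and no clear rank can be given to it.

Compound 4 (`O=C(CC1CCCCC1)Nc1ccc(Nc2nccc(NC3CCCC3)n2)cc1`) departs from compound 3 in one place, with cyclohexylmethyl in place of cyclohexylamino on a carbonyl carbon.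

For the measured compounds named here, no measured step covers this change. The only one available, a 3.5-fold higher number from compound 1 to compound 2 (0.55 log units; beyond the scatter), is modest and swaps cyclopropyl for cyclohexyl on a nitrogen on an aromatic ring, which is a different place. It shows only that one change among these compounds can move the number beyond the scatter, and it gives no direction here. In this assay, no step beyond the scatter is therefore expected, and the estimated step is a 1.1-fold higher number from compound 3 to compound 4 (0.06 log units; within the scatter). For compound 4 the expected value is 22000 nM, with an estimated range from 8000 nM to 60000 nM.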

Compound 4, half-maximal inhibitory concentration: 17600 nM
Estimate against measurement, compound 4: 1.3-fold (0.10 log units) above, within the range that was stated.
By their numbers in this assay, from the lowest: compounds 1, 4, 3 and 2 (each within the scatter of the next, the first and the last beyond it).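

In this assay, cyclohexylmethyl in place of cyclohexylamino on a carbonyl carbon gives a 1.1-fold lower number from compound 3 to compound 4 (0.04 log units; within the scatter). For the compounds shown here, this is the first reading at this position, as the only earlier step concerned a nitrogen on an aromatic ring. In this one pair, the six-membered carbon ring is retained while the hydrogen-bond donor of cyclohexylamino is lost, and the number stays within the scatter. No accompanying evidence bears on the reason for this result.

The compounds shown leave open whether a piperidine or a carboxylic acid carried on the carbonyl carbon would move the number beyond the scatter. They also leave open whether the same exchange would read alike with cyclohexyl or cyclopropyl on the nitrogen on an aromatic ring.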